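The compounds below may be only part of what the source reports. "The series", "measured", "known", "first", "only" and "open" are said of these compounds alone.

Measured so far in a functional assay on HL-60 cells (Homo sapiens) for antiproliferative activity; a higher number here means a weaker inhibitor, a lower number a stronger inhibitor:
Compound 1 `CCOC(=O)c1ccc(Oc2ccc(OC)cc2)cc1O` gives > 30000 nM, a limit of the assay.
Compound 2 `CCOC(=O)c1ccc(Oc2ccc(OC)c(OC)c2)cc1O` gives 1500 nM.
Compound 3 `COC(=O)c1ccc(Oc2ccc(OC)cc2)c([N+](=O)[O-])c1` gives > 20000 nM, a limit of the assay.

The change from compound 1 to compound 2 is methoxy in place of hydrogen on an aromatic carbon. It brought an at least 20-fold lower number from compound 1 to compound 2 (1.30 log units; beyond the scatter), the step being measured from the limit of > 30000 nM in this assay, at which 1 of the 3 values shown sits. Compound 4 `COC(=O)c1ccc(Oc2ccc(OC)c(OC)c2)c([N+](=O)[O-])c1` has not yet been measured in this assay. It carries the same change relative to compound 3, (methoxy in place of hydrogen on an aromatic carbon), with the same surroundings of the place. How the core of compound 3 differs from the core of compound 1 is not broken down here. Compound 3 sits at the limit of > 20000 nM in this assay, at which 1 of the 3 values shown sits. Because the same change gave an at least 20-fold lower number from compound 1 to compound 2 (1.30 log units; beyond the scatter) from a starting limit, a large step downward is expected from compound 3 to compound 4, though the start for compound 3 is itself only a limit, so the size rests on one earlier pair. The expected step is an at least 6.6-fold lower number from compound 3 to compound 4 (0.82 log units; beyond the scatter). Compound 4 is expected to give 3000 nM in this assay. Its estimated range runs from 800 nM to 20000 nM.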

Compound 4, half-maximal inhibitory concentration: > 20000 nM
Compound 4 was reported as a limit; the forecaster's own chance of this, stated with the estimate: 25%; at least 6.6-fold (0.82 log units) between middle value and limit.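

In this assay, compound 3 and compound 4 both stand at the same limit of the assay, so no step between them can be read: the limit of > 20000 nM in this assay, at which 2 of the 4 values shown sit.

The compounds shown leave open whether methoxy in place of hydrogen on an aromatic carbon changes the number at all on the core of compound 3.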